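Same Atoms, One Undrawn Stereocentre

A few compounds are considered here, and "the series" means these few. Any claim that something is new, unique, unknown or untested is made for them only; others in the source may bear on it.

Compound 1 `CCCCCC(CCO)n1cnc2c(Cl)ncnc21`: > 50000 nM
Compound 2 `CCCCCCCCC[C@@H](CCO)n1cnc2c(Cl)ncnc21`: 1050 nM

Both compounds were tested in a functional assay on HCT-116 cells (Homo sapiens) for antiproliferative activity, read by MTT assay, with a stated time of 48 h; a higher number here means a weaker inhibitor, a lower number a stronger inhibitor. For compound 1, the entry > 50000 nM is a limit of the assay and not a number. Within the data shown here, that makes compound 2, at 1050 nM, the only compound with an exact value so far, so there is no second number to rank it against.

The next compound is compound 3 `CCCCCCCCCC(CCO)n1cnc2c(Cl)ncnc21`. Its difference from compound 2 is small: the two compounds have the same atoms and bonds; at least one stereo element is drawn with a configuration in one of them and without one in the other: 1 of 1 stereo elements differ; a stereocentre at a saturated chain carbon is drawn S in compound 2 and without a configuration in compound 3. Among the measured compounds shown here, no measured pair yet shows what such a change does in this assay, so the expectation rests on compound 2 at 1050 nM alone. Only a small shift towards weaker inhibition is expected, within the usual scatter. The expected change is a 1.3-fold higher number from compound 2 to compound 3 (0.12 log units; within the scatter). Compound 3 is estimated at 1400 nM, with an expected range of 600 nM to 3200 nM.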

Compound 3, half-maximal inhibitory concentration: 890 nM
Beside the measured number, compound 3's estimate is 1.6-fold (0.20 log units) above it, and the stated range covers the measured number.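

In this assay, leaving the stereocentre undrawn gives a 1.2-fold lower number from compound 2 to compound 3 (0.07 log units; within the scatter), so drawing this carbon as S or leaving it undrawn brings no change that can be told apart from the scatter. The chain is a different matter: butyl in place of hydrogen on a saturated chain carbon, six bonds along the chain from an aromatic nitrogen, gives an at least 56-fold lower number from compound 1 to compound 3 (1.74 log units; beyond the scatter), the first readable effect at this position. The entry for compound 1 is a limit of the assay and not a number: the limit of > 50000 nM in this assay, at which 1 of the 3 values shown sits.

The compounds shown do not include the R form, so they leave open whether the two configurations differ in activity, and the only comparison at this carbon is this one: the fact that one of compounds 2 and 3 is drawn with a defined configuration and the other without, at the place where they differ It also remains open whether a longer chain at this carbon would give a lower number still.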